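A few compounds are considered here, and "the series" means these few. Any claim that something is new, unique, unknown or untested is made for them only; others in the source may bear on it.

For the measured compounds named here, compound 2 `CC(C)Nc1sc(C(=O)c2ccc(Br)s2)c(N)c1C#N` is the only compound in this set with a numerical potency: in an assay for inhibition of Maternal embryonic leucine zipper kinase (Homo sapiens), read by ADP-Glo, with a stated time of 0.5 h (a higher number here means a weaker inhibitor, a lower number a stronger inhibitor), compound 2 gives 122 nM. Its companion, compound 1 `CC(C)Nc1sc(C(=O)c2cccnc2)c(N)c1C#N`, shares the core but carries pyridin-3-yl on the carbonyl carbon. In this assay compound 1 reaches only a limit, > 5000 nM, which marks the edge of the measurement rather than a number. Going by the values given here, the one step that links these two, an at least 40-fold lower number from compound 1 to compound 2 (1.61 log units; beyond the scatter), therefore rests on that limit of > 5000 nM in this assay, at which 1 of the 2 values shown sits, and tells only how far compound 2 lies beyond it.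

Compound 3 `CC(C)Nc1sc(C(=O)c2ccc(I)s2)c(N)c1C#N` differs from compound 2 by a single exchange: iodo in place of bromo on an aromatic carbon. Among the compounds with values here, no measured pair in this set touches such a halogen swap; the step from compound 1 to compound 2 replaces the whole aromatic ring and does not bear on the size of the halogen at this position. With nothing in the data pointing either way, compound 3 is expected to sit close to compound 2, with a 1.2-fold lower number from compound 2 to compound 3 (0.09 log units; within the scatter) as the expected step, within the usual scatter. Compound 3 is accordingly estimated at 100 nM in this assay, with a range from 40 nM to 300 nM.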

Compound 3, half-maximal inhibitory concentration: 112 nM
Compound 3: the middle estimate sits 1.1-fold (0.05 log units) below what was measured, and the stated range covers the measured number.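

In this assay, iodo in place of bromo on the five-membered aromatic ring with 1 sulfur comes to a 1.1-fold lower number from compound 2 to compound 3 (0.04 log units; within the scatter), so the two halogens at this position cannot be told apart by this measurement. 5-iodothiophen-2-yl in place of pyridin-3-yl on the carbonyl carbon comes to an at least 44-fold lower number from compound 1 to compound 3 (1.64 log units; beyond the scatter), which shows that the large step first seen with 5-bromothiophen-2-yl does not depend on bromo alone. This step starts from a value for compound 1 that is a limit and not a number: the limit of > 5000 nM in this assay, at which 1 of the 3 values shown sits.

From the compounds shown here alone, whether a smaller halogen such as chloro, or a methyl or an amine, would hold this potency at the same position remains open. Also open, going by these compounds, is what plain thiophen-2-yl, with only a hydrogen in that place, would give, and that is the comparison that would separate the contribution of the ring from that of the halogen on it.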